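A few compounds are considered here, and "the series" means these few. Any claim that something is new, unique, unknown or untested is made for them only; others in the source may bear on it.

Measured compounds:
compound 1 `O=C(O)[C@H]1NCC=C[C@@H]1O`: 25%
compound 2 `O=C(O)[C@H]1NC[C@H](O)[C@H](O)[C@H]1O`: 21%
compound 3 `O=C(O)[C@H]1NCC=C[C@H]1O`: 0.2%

In an assay for inhibition of alpha-N-acetylgalactosaminidase (Gallus gallus), tested at 1000 uM (on this read-out lower numbers stand for less inhibition and higher numbers for more inhibition at the one concentration tested (going by the name of the read-out)), compound 2 stands second highest of the three. Its value and that of compound 1 lie within the scatter of each other, while compound 3 sits well below both. Compound 4 `O=C(O)[C@@H]1NC[C@H](O)[C@@H](O)[C@@H]1O` relates to compound 2 as follows: the two compounds have the same atoms and bonds and differ only in configuration as drawn: 3 of 4 stereo elements differ; a stereocentre at a saturated ring carbon is drawn S in compound 2 and R in compound 4; a stereocentre at a saturated ring carbon is drawn S in compound 2 and R in compound 4; a stereocentre at a saturated ring carbon is drawn S in compound 2 and R in compound 4. Among the measured compounds shown here, the one measured step of this kind is a number 24.8 percentage points lower from compound 1 to compound 3 (beyond the scatter), and that step rests on (the fact that compounds 1 and 3 differ only in the configuration as drawn). Since compound 4 changes the drawn configuration at three saturated ring carbons rather than one, a downward step beyond the scatter is expected. Compound 4 is expected to give 5%, with a range from 0% to 25%. This estimate means an expected step of a number 16 percentage points lower from compound 2 to compound 4 (beyond the scatter).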

Compound 4, a percentage reported as inhibition, at one concentration (the size of the read-out at that concentration, not a potency): 3.4%
The estimate for compound 4 lay 1.6 percentage points above the measured number; the range from low to high includes it.
By their numbers in this assay, from the lowest: compounds 3 and 4 (each within the scatter of the next); then compounds 2 and 1 (each within the scatter of the next).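

In this assay the new pair gives a number 17.6 percentage points lower from compound 2 to compound 4 (beyond the scatter), so the sensitivity to drawn configuration is not confined to the core of compound 1 but also appears on the core of compound 2. Atoms and bonds stay the same, so the drop rests on configuration alone: the fact that compounds 2 and 4 differ only in the configuration as drawn Three saturated ring carbons change at once, so the share of each one cannot be separated.

From the compounds shown here alone, whether a single change of configuration on the core of compound 2 would be enough remains open. Also open, going by these compounds, is how either core behaves when a primary amide or a hydroxymethyl group replaces the carboxylic acid.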